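A few compounds are considered here, and "the series" means these few. Any claim that something is new, unique, unknown or untested is made for them only; others in the source may bear on it.

In a functional assay on MDA-MB-231 cells (Homo sapiens) for cytotoxicity, read by MTT assay, with a stated time of 72 h (a higher number here means a weaker inhibitor, a lower number a stronger inhibitor), compound 2 `O=C1c2c[n+]([O-])c3ccccc3c2C(=O)c2c1c1ccccc1n2Cc1cn([C@@H]2C[C@H](O)[C@@H](CO)O2)nn1` gives 130 nM. Compound 1 `CN(C)CCCCCn1c2c(c3ccccc31)C(=O)c1c[n+]([O-])c3ccccc3c1C2=O` gives 240 nM, within the usual scatter of that number, while compound 3 `CCCCN1CCN(CCCCn2c3c(c4ccccc42)C(=O)c2c[n+]([O-])c4ccccc4c2C3=O)CC1` gives 900 nM, a clearly higher number. Compound 4 `CC1(C)OC[C@@H](Cn2cc(Cn3c4c(c5ccccc53)C(=O)c3c[n+]([O-])c5ccccc5c3C4=O)nn2)O1` differs from compound 2 by this change on an aromatic nitrogen: (2,2-dimethyl-1,3-dioxolan-4-yl)methyl in place of 4-hydroxy-5-(hydroxymethyl)oxolan-2-yl on an aromatic nitrogen. For the measured compounds named here, no measured compound pair makes this swap. Going by the values given here, the one measured step, a 3.8-fold higher number from compound 1 to compound 3 (0.57 log units; beyond the scatter), involves other groups at another place, so it shows only that changing a side group can move the number modestly. A small rise, not clearly beyond the scatter, is therefore expected. The estimated step is a 1.5-fold higher number from compound 2 to compound 4 (0.19 log units; within the scatter). For compound 4 the estimated value is 200 nM, with an expected range from 70 nM to 600 nM.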

Compound 4, half-maximal inhibitory concentration: > 1000 nM
Compound 4: only a limit was reported; the forecaster's own chance of this, stated with the estimate: 3%; at least 5.0-fold (0.69 log units) between middle value and limit.
By their numbers in this assay, from the lowest: compounds 2 and 1 (each within the scatter of the next); then compound 3. At a limit, above all of these: compound 4.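

For the compounds shown here, on this aromatic nitrogen, the choice of group can matter far more than the earlier compounds showed: the change gives an at least 7.6-fold higher number from compound 2 to compound 4 (0.88 log units; beyond the scatter). In this assay, on these data alone, compound 4 reaches only a limit, > 1000 nM, so the full size of this step stays unknown. The leaving group has 2 hydrogen-bond donors and the entering group 0 hydrogen-bond donors, but the ring and the stereocentres change too, so this one pair cannot single out what moved the number. As far as these compounds go, how an open-chain diol, an amine or a carboxylic acid on this nitrogen would read remains open.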